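The compounds below may be only part of what the source reports. "The series", "measured", "known", "first", "only" and "open" are said of these compounds alone.

Compound 1 `COc1cc(-c2nn(-c3cccc(NC(=O)Nc4ccc(Cl)c(Cl)c4)c3)cc2-c2ccncc2)ccc1Cl`: in a functional assay on OVCAR-3 cells (Homo sapiens) for inhibition, read by sulforhodamine B assay, with a stated time of 48 h (a higher number here means that more compound is tolerated, a lower number that less compound is tolerated), compound 1 gives only a limit, > 50000 nM.
Compound 2 `O=C(Nc1cccc(-n2cc(-c3ccncc3)c(-c3ccc(Cl)c(O)c3)n2)c1)Nc1ccc(Cl)c(Cl)c1`: in this assay compound 2 gives only a limit, > 32500 nM.
Compound 3 `COc1cc(-c2nn(-c3cccc(NC(=O)c4ccc(Cl)c(C(F)(F)F)c4)c3)cc2-c2ccncc2)ccc1Cl`: in this assay compound 3 gives only a limit, > 32500 nM.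

Compound 2 therefore stands at a limit, and the two other values shown are limits as well, as the limit of > 32500 nM in this assay, at which 2 of the 3 values shown sit, and the limit of > 50000 nM in this assay, at which 1 of the 3 values shown sits, record. The step from compound 1 to compound 2 a step that the two limits leave unreadable from compound 1 to compound 2 and the step from compound 1 to compound 3 a step that the two limits leave unreadable from compound 1 to compound 3 both have no readable size, since both ends are limits. Compound 4 `O=C(Nc1cccc(-n2cc(-c3ccncc3)c(-c3ccc(Cl)c(O)c3)n2)c1)Nc1ccc(Cl)c(C(F)(F)F)c1` differs from compound 2 by trifluoromethyl in place of chloro on an aromatic carbon. Going by the values given here, the only measured step that touches this change is the one from compound 1 to compound 3 a step that the two limits leave unreadable from compound 1 to compound 3, which carries the same swap of trifluoromethyl for chloro together with a further change on the carbonyl, and it too gave nothing readable. No step beyond the scatter is therefore expected in this assay, and the most likely outcome for compound 4 is again a limit. Compound 4 is accordingly expected to give about 50000 nM, within 20000 nM to 100000 nM. The expected step from compound 2 to compound 4 is thus a step that the limit leaves unreadable from compound 2 to compound 4, that is, none beyond the scatter.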

Compound 4, concentration lethal to 50% of the cells: > 32500 nM
Compound 4: only a limit was reported; the forecaster's own chance of this, stated with the estimate: 85%; the middle value does not contradict the limit.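

Compound 2 and compound 4 both give only a limit in this assay, so the swap of trifluoromethyl for chloro yields no readable step. The compounds shown leave open what size, if any, this swap or the other changes have in this assay.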